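This account rests on a few compounds, and the source may have more. Where it says the series, first, only, none or still open, it means among the compounds named here.

Compound 1, `CC1(C)CCCN(CCCC2=CCc3ccccc32)C1`, and compound 2, `CC1(C)CCCN(CCCC2CCc3ccccc32)C1`, share a core and differ in the ring fused to the benzene, one carrying a double bond and the other fully saturated. In an assay on cell membranes for binding affinity to Sigma non-opioid intracellular receptor 1 (Rattus norvegicus), read by radioligand binding (a higher number here means a weaker inhibitor, a lower number a stronger inhibitor), compound 1 gives 0.99 nM and compound 2 gives 6.9 nM, so compound 2 stands with the higher of the two numbers, and its gap to compound 1 lies beyond the usual scatter of such measurements. Compound 3, `COc1ccc2c(c1)CCC2CCCN1CCCC(C)(C)C1`, is built on the saturated core of compound 2 and is reached by one change: methoxy in place of hydrogen on an aromatic carbon. Among the measured compounds shown here, no measured pair in this set shows the effect of such a substitution, so the expected size of the step in this assay can rest only on the structural change itself. It is expected that compound 3 differs little from compound 2, with the step of a 1.4-fold lower number from compound 2 to compound 3 (0.14 log units; within the scatter) estimated to stay within or close to the scatter. For compound 3 the estimate in this assay is 5 nM, with a likely range from 1.5 nM to 20 nM.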

Compound 3, half-maximal inhibitory concentration: 4660 nM
Compound 3: middle estimate off by 930-fold (2.97 log units), on the low side, outside the stated range (above it).
By their numbers in this assay, from the lowest: compound 1; then compound 2; then compound 3.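

In this assay the aromatic carbon meta to a fused ring and para to a fused ring proves highly sensitive to substitution, as methoxy in place of hydrogen there gives a 680-fold higher number from compound 2 to compound 3 (2.83 log units; beyond the scatter) in a single change. Among the compounds shown here, the earlier pair varied only the ring fused to the benzene and left the aromatic positions untouched, and compound 1 at 0.99 nM and compound 2 at 6.9 nM gave no sign that a change of two heavy atoms on the aromatic ring could shift the number so far. No available information accounts for the size of this step.

The compounds shown leave open whether this step belongs to methoxy in particular or would also follow from a smaller group on the same carbon, such as a fluorine atom, a hydroxyl or a methyl. They also leave open whether methoxy would give a similar step on another aromatic carbon, or on the core of compound 1 with its double bond.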